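Replacing the aryl group on the shared core

A few compounds are considered here, and "the series" means these few. Any claim that something is new, unique, unknown or untested is made for them only; others in the source may bear on it.

Values so far in a physicochemical assay for lipophilicity; a lower number here means a more polar compound, a higher number a more lipophilic compound:

compound 1 `COC(=O)C[C@H](O)C[C@H](O)/C=C/n1c(C(C)C)cc(-c2ccncc2)c1-c1ccc(F)cc1` gives 0.9
compound 2 `COC(=O)C[C@H](O)C[C@H](O)/C=C/n1c(C(C)C)cc(-c2ccc(F)cc2)c1-c1ccc(F)cc1` gives 2.1

Compound 2 stands highest of the two numbers. Within the data shown here, the only measured step is a number 1.20 log units higher from compound 1 to compound 2 (beyond the scatter) and it is large, with 4-fluorophenyl in place of pyridin-4-yl on an aromatic carbon. The next structure is compound 3 `COC(=O)C[C@H](O)C[C@H](O)/C=C/n1c(C(C)C)cc(-c2cccc(Cl)c2)c1-c1ccc(F)cc1` and its difference from compound 2 is 3-chlorophenyl in place of 4-fluorophenyl on an aromatic carbon. That measured step bears on this change only loosely: it removed pyridin-4-yl, whereas both groups here are six-membered aromatic rings of carbon only. A much smaller step in this assay is therefore expected, modestly upward and possibly not beyond the scatter. The estimated change is a number 0.30 log units higher from compound 2 to compound 3 (within the scatter). The expected value for compound 3 is 2.4 with an estimated range of 2 to 2.8.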

Compound 3, distribution coefficient: 2.57
Beside the measured number, compound 3's estimate is 0.17 log units below it, and the stated range covers the measured number.
By their numbers in this assay, from the lowest: compound 1; then compound 2; then compound 3.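

In this assay, this position still separates two aryl groups that both are six-membered aromatic rings of carbon only: 3-chlorophenyl in place of 4-fluorophenyl gives a number 0.47 log units higher from compound 2 to compound 3 (beyond the scatter), a step that the pyridin-4-yl comparison could not reveal. Against pyridin-4-yl, 3-chlorophenyl gives a number 1.67 log units higher from compound 1 to compound 3 (beyond the scatter), so the range at this position now spans more than the earlier single step showed. The halogen and its place on the ring change together in this swap, and no available evidence accounts for the shift.

The compounds shown do not separate the halogen from its place on the ring, which 3-fluorophenyl or 4-chlorophenyl would address. From the compounds shown here alone, how this position responds to an aryl ring bearing an amine or a carboxylic acid also remains open.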